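A few compounds are considered here, and "the series" means these few. Any claim that something is new, unique, unknown or untested is made for them only; others in the source may bear on it.

Furan in place of thiophene on a shared pyridine-free core? No — title must avoid naming rings.

Title: Compound 4, a Furanyl Analogue of Compound 2

Three compounds have been measured in a functional assay on HCT-15 cells (Homo sapiens) for cytotoxicity, read by CCK-8 assay; a higher number here means a weaker inhibitor, a lower number a stronger inhibitor:
Compound 1 `Oc1ccccc1-c1cc(-c2cccs2)cc(-c2ccccc2O)n1` gives > 50000 nM, a limit of the assay.
Compound 2 `Oc1ccccc1-c1cc(-c2ccsc2)cc(-c2ccccc2O)n1` gives > 50000 nM, a limit of the assay.
Compound 3 `Oc1cccc(-c2cc(-c3ccsc3)cc(-c3ccccc3O)n2)c1` gives > 50000 nM, a limit of the assay.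

Compound 2 therefore stands only at a limit, as do both of its neighbours, a situation summarised by the limit of > 50000 nM in this assay, at which 3 of the 3 values shown sit. The step that the two limits leave unreadable from compound 1 to compound 2 and the step that the two limits leave unreadable from compound 2 to compound 3 are both unreadable for that reason. Compound 4 `Oc1ccccc1-c1cc(-c2ccco2)cc(-c2ccccc2O)n1` differs from compound 2 by furan-2-yl in place of thiophen-3-yl on an aromatic carbon. Among the measured compounds shown here, no measured step bears readably on this change, and the three values give no sign of any measurable potency. Compound 4 is therefore expected to remain at the limit, with the step that the limit leaves unreadable from compound 2 to compound 4 estimated as no change beyond the scatter. The estimate for compound 4 in this assay is 100000 nM, within 30000 nM to 300000 nM.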

Compound 4, half-maximal inhibitory concentration: > 50000 nM
Compound 4: a limit, no number; the forecaster's own chance of this, stated with the estimate: 85%; the middle value does not contradict the limit.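

In this assay, compound 4 gives > 50000 nM, a limit of the assay, so the steps to compound 4 from compound 1 and compound 2 cannot be read. The compounds shown leave open whether any change to the shared core would give a readable number: the limit of > 50000 nM in this assay, at which 4 of the 4 values shown sit.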